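Cytotoxicity in kidney cells: swapping benzyloxy for ethoxy

This account rests on a few compounds, and the source may have more. Where it says the series, first, only, none or still open, it means among the compounds named here.

Of the compounds shown here, three have been tested in an ADME assay on HEK293 cells (Homo sapiens) for cytotoxicity, read by CellTiter-Glo and resazurin assay, with a stated time of 72 h; on this read-out lower numbers stand for an effect already at smaller amounts and higher numbers for an effect only at larger amounts of compound. Compound 1 `CCOc1cccc(-c2ccc(C(=O)N(Cc3cccc(OCCCCCC(=O)O)c3)C(C)C)cc2)c1` gives a value that is only a limit of the measurement, > 20800 nM. Compound 2 `CCOC(=O)CCCCCOc1cccc(CN(C(=O)c2ccc(-c3ccc(C(C)=O)s3)cc2)C(C)C)c1` likewise reaches only a limit, > 26000 nM. Compound 3 `CCOC(=O)CCCCCOc1cccc(CN(C(=O)c2ccc(-c3cccc(OCc4ccccc4)c3)cc2)C(C)C)c1` also stops at a limit, > 26000 nM. So for all three compounds no number is known, only the boundary that each measurement reached: the limit of > 20800 nM in this assay, at which 1 of the 3 values shown sits, and (the limit of > 26000 nM in this assay, at which 2 of the 3 values shown sit). None of the three shows a cytotoxic effect within the range examined, and nothing separates them from one another on these figures.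

Compound 4 `CCOC(=O)CCCCCOc1cccc(CN(C(=O)c2ccc(-c3cccc(OCC)c3)cc2)C(C)C)c1` has not been measured yet. It differs from compound 3 in one place: methyl in place of phenyl on a saturated chain carbon bound to an oxygen on an aromatic ring, which means that a benzyloxy group on the aromatic ring becomes an ethoxy group. Within the data shown here, since compound 3 gives only a limit, no step within the measured compounds can guide the expectation, and the expected step that the limit leaves unreadable from compound 3 to compound 4 is none beyond the usual scatter. On this basis compound 4 is estimated to give around 40000 nM in this assay, within a range from 20000 nM to 150000 nM, with a result that most likely again ends at a limit rather than a number.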

Compound 4, half-maximal effective concentration: > 22300 nM
Compound 4: only a limit was reported; the forecaster's own chance of this, stated with the estimate: 85%; the middle value lies beyond the limit too.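

The result for compound 4 is again only a limit, as are those for compound 1, compound 2 and compound 3, so the steps from these three compounds to compound 4 cannot be read. The compounds shown leave open at what concentration, if any, each would harm the cells, and whether replacing benzyloxy with ethoxy changes that concentration.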